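A Hydroxyl for a Fluorine on the Benzamide Ring

The source may report more compounds than this note shows. Statements on the series, on what has been measured and on what is new or still open speak of the compounds shown alone.

Compound 1, `Cc1ccc(S(=O)(=O)N[C@@H](CC(=O)NC(C)(C)C)C(=O)NCCNC(=O)c2ccc(F)cc2)cc1`, was tested in an ADME assay on Karpas-1106P cells (Homo sapiens) for cytotoxicity; on this read-out lower numbers stand for an effect already at smaller amounts and higher numbers for an effect only at larger amounts of compound. There compound 1 gives > 11100 nM, which is a limit of the assay rather than a number. Compound 2, `Cc1ccc(S(=O)(=O)N[C@@H](CC(=O)NC(C)(C)C)C(=O)NCCNC(=O)c2cc(Cl)ccc2Cl)cc1`, likewise sits at a limit, > 11100 nM. Compound 3, `Cc1ccc(S(=O)(=O)N[C@@H](CC(=O)NC(C)(C)C)C(=O)NCCNC(=O)NCc2ccccc2)cc1`, also reaches only a limit, > 11100 nM. All three rest at the same point, (the limit of > 11100 nM in this assay, at which 3 of the 3 values shown sit), so the steps a step that the two limits leave unreadable from compound 1 to compound 2, a step that the two limits leave unreadable from compound 1 to compound 3 and a step that the two limits leave unreadable from compound 2 to compound 3 carry no readable size or direction. Compound 4, `Cc1ccc(S(=O)(=O)N[C@@H](CC(=O)NC(C)(C)C)C(=O)NCCNC(=O)c2ccccc2O)cc1`, differs from compound 1 by 2-hydroxyphenyl in place of 4-fluorophenyl on a carbonyl carbon. Going by the values given here, no measured step touches this change, and the three limits give no ground for expecting a readable movement in this assay beyond the scatter. Compound 4 is therefore expected to sit again near the limit, at an estimated 20000 nM within 8000 nM to 50000 nM. For compound 4 the expected step is a step that the limit leaves unreadable from compound 1 to compound 4.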

Compound 4, half-maximal effective concentration: > 11100 nM
Compound 4 gave a limit, no number; the forecaster's own chance of this, stated with the estimate: 85%; the middle value is on the limit's open side.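

Going by these compounds alone, compound 4 also gives only a limit, so no step linking it to compound 1, compound 2 or compound 3 can be read: the limit of > 11100 nM in this assay, at which 4 of the 4 values shown sit. On these data alone, how far beyond that limit each compound lies stays open, and with it whether 2-hydroxyphenyl in place of 4-fluorophenyl changes anything.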